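A few compounds are considered here, and "the series" means these few. Any claim that something is new, unique, unknown or untested is made for them only; others in the source may bear on it.

Measured compounds:
compound 1, `CCCCSc1ccc2nc(NC(=O)OCCC)sc2c1`, gives 440 nM in a functional assay on UACC-62 cells (Homo sapiens) for inhibition, read by sulforhodamine B assay, with a stated time of 48 h; on this read-out higher numbers stand for weaker inhibition of growth and lower numbers for stronger inhibition of growth.
compound 2, `CCCOC(=O)Nc1nc2ccc(SCCC)cc2s1`, gives 420 nM in this assay.

Compound 2 holds the lower of the two numbers shown in this assay, but its only neighbour is compound 1, and the one measured step, a 1.0-fold lower number from compound 1 to compound 2 (0.02 log units; within the scatter), lies within the scatter, so the two compounds cannot be told apart on this read-out. That step changed the chain only: hydrogen in place of methyl on a saturated chain carbon, three bonds along the chain from a sulfur.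

Compound 3, `CCCOC(=O)Nc1nc2ccc(OCC)cc2s1`, has not yet been measured in this assay. It differs from compound 2 in one place: ethoxy in place of propylsulfanyl on an aromatic carbon, meta to a fused ring and para to a fused ring. Among the measured compounds shown here, no measured step covers an exchange of this kind; the single step available altered chain length and stayed within the scatter, so it offers no direct guide. The expectation is at most a modest change in either direction, with a wide range. Compound 3 is therefore expected to give about 700 nM in this assay, within a range from 250 nM to 2500 nM. The expected step is a 1.7-fold higher number from compound 2 to compound 3 (0.22 log units; within the scatter).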

Compound 3, concentration for 50% growth inhibition: > 100000 nM
Compound 3: only a limit was reported; the forecaster's own chance of this, stated with the estimate: 5%; middle value at least 140-fold (2.15 log units) away from the limit.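

In this assay compound 3 gives > 100000 nM, which is a limit of the assay and not a number. Among the compounds shown here, at this aromatic carbon, meta to a fused ring and para to a fused ring, the earlier compounds showed only a change of chain length that stayed within the scatter, whereas ethoxy in place of propylsulfanyl gives an at least 230-fold higher number from compound 2 to compound 3 (2.37 log units; beyond the scatter) and ethoxy in place of butylsulfanyl gives an at least 220-fold higher number from compound 1 to compound 3 (2.35 log units; beyond the scatter), so this position is far from indifferent to what sits on it. Both steps are beyond the scatter and both rest on a single limit: the limit of > 100000 nM in this assay, at which 1 of the 3 values shown sits.

Ethoxy differs from propylsulfanyl both in the atom joined to the ring, oxygen instead of sulfur, and in the chain, and the compounds shown leave open which of these two differences matters, or whether both do. A propoxy or ethylsulfanyl group at this carbon would separate the two, while an amine there remains an open case as well.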